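A few compounds are considered here, and "the series" means these few. Any claim that something is new, unique, unknown or untested is made for them only; others in the source may bear on it.

Series notes. In a functional assay, with a stated time of 150 min, tested at 35 ug/mL (on this read-out lower numbers stand for a weaker effect and higher numbers for a stronger effect at the one concentration tested), compound 1 `COC(=O)c1c(Nc2ccccc2)sc(C(=O)c2ccc(OC)cc2)c1C` gives 63%. Compound 2 `COC(=O)c1c(Nc2ccc(C)cc2)sc(C(=O)c2ccc(OC)cc2)c1C` is recorded in this assay as "not active" (no number reported). Compound 3 `COC(=O)c1c(Nc2ccc(F)cc2)sc(C(=O)c2ccc(OC)cc2)c1C` gives 25.6%, the lowest of the two numbers shown, with compound 1 as its nearest neighbour. Compound 4 `COC(=O)c1c(Nc2ccc(Cl)cc2)sc(C(=O)c2ccc(OC)cc2)c1C` differs from compound 3 by chloro in place of fluoro on an aromatic carbon. Among the measured compounds shown here, no measured step exchanges one halogen for another, so the expectation rests on the large drop a number 37.4 percentage points lower from compound 1 to compound 3 (beyond the scatter) and on the missing number for compound 2. Compound 4 is therefore expected to come in low, with a step of a number 7.6 percentage points lower from compound 3 to compound 4 (within the scatter) that lies within the scatter, estimated at 18% in a range from 0% to 45%.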

Compound 4, a percentage reported as activity, at one concentration (the size of the read-out at that concentration, not a potency): "not active" (no number reported)
No number was reported for compound 4; there is nothing to compare the estimate with.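

Among the compounds shown here, compound 4 carries no number in this assay, so no step from compound 3 to compound 4 can be read. Nothing at hand speaks to a cause. The compounds shown leave open where compound 2 and compound 4 stand numerically relative to compound 3.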